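This account rests on a few compounds, and the source may have more. Where it says the series, first, only, none or still open, it means among the compounds named here.

Measured so far in a functional assay on HCT-116 cells (Homo sapiens) for cytotoxicity, read by MTT assay, with a stated time of 72 h; a lower number here means a stronger inhibitor, a higher number a weaker inhibitor:
compound 1 `Cc1ccc(S(=O)(=O)c2nc3ccccc3nc2N2CCc3ccccc3C2)cc1` gives 39000 nM
compound 2 `COc1ccc(S(=O)(=O)c2nc3ccccc3nc2N2CCc3ccccc3C2)cc1` gives 22100 nM
compound 3 `Cc1ccc(S(=O)(=O)c2nc3ccccc3nc2N2CCC(O)CC2)cc1` gives 5440 nM

Not yet measured: compound 4 `COc1ccc(S(=O)(=O)c2nc3ccccc3nc2N2CCC(O)CC2)cc1`.

Compounds 1 and 2 share the same core and differ in one place only: methoxy in place of methyl on an aromatic carbon The step this change made is a 1.8-fold lower number from compound 1 to compound 2 (0.25 log units; within the scatter), so the two numbers cannot be told apart. Compound 3 carries a different group on the shared core; how it differs from compound 1 is: 4-hydroxypiperidin-1-yl in place of 1,2,3,4-tetrahydroisoquinolin-2-yl on an aromatic carbon That change gave a 7.2-fold lower number from compound 1 to compound 3 (0.86 log units; beyond the scatter), and compound 3 holds the lowest number of the three measured compounds. Compound 4 differs from compound 3 in the same way that compound 2 differs from compound 1: methoxy in place of methyl on an aromatic carbon The surroundings of the changed carbon read the same in both pairs, so this is the same change made on a different core. Because the earlier step of a 1.8-fold lower number from compound 1 to compound 2 (0.25 log units; within the scatter) stayed within the scatter, the step expected here, a 1.6-fold lower number from compound 3 to compound 4 (0.19 log units; within the scatter), is estimated to be of similarly small size. Compound 4 is therefore expected to give about 3500 nM in this assay, with a likely range from 1200 nM to 10000 nM.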

Compound 4, half-maximal inhibitory concentration: 4690 nM
Beside the measured number, compound 4's estimate is 1.3-fold (0.13 log units) below it; the measured number falls inside the stated range.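

In this assay, methoxy in place of methyl gives a 1.2-fold lower number from compound 3 to compound 4 (0.06 log units; within the scatter), a small step that matches the one seen on the other core: the same change on two cores in this assay, a 1.8-fold lower number (0.25 log units; within the scatter) from compound 1 to compound 2 and a 1.2-fold lower number (0.06 log units; within the scatter) from compound 3 to compound 4, 1.5-fold (0.18 log units) apart, within the scatter of two such steps

The larger change, 4-hydroxypiperidin-1-yl in place of 1,2,3,4-tetrahydroisoquinolin-2-yl, gives a 4.7-fold lower number from compound 2 to compound 4 (0.67 log units; beyond the scatter), and it too carries over between the two cores: the same change on two cores in this assay, a 7.2-fold lower number (0.86 log units; beyond the scatter) from compound 1 to compound 3 and a 4.7-fold lower number (0.67 log units; beyond the scatter) from compound 2 to compound 4, 1.5-fold (0.18 log units) apart, within the scatter of two such steps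

Across these four compounds, each change therefore behaves much the same whichever form of the other group is present, but for methoxy what carries over is a step too small to read as a real gain, and two pairs cannot show that either change would behave the same way on other cores.

The compounds shown leave open whether a chlorine atom or a nitrile in place of the methyl or methoxy would move the number. They also leave open how a plain piperidin-1-yl group, or a piperidine carrying an amine or a carboxylic acid instead of the hydroxy group, would compare with 4-hydroxypiperidin-1-yl.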